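Moving the Ring Nitrogen in a Weak Sulfatase Inhibitor

The source may report more compounds than this note shows. Statements on the series, on what has been measured and on what is new or still open speak of the compounds shown alone.

Of the compounds shown here, three sharing one core have been measured in an assay on T47D cells for inhibition of Steryl-sulfatase (Homo sapiens), read by HPLC, with a stated time of 24 h; on this read-out lower numbers stand for stronger inhibition and higher numbers for weaker inhibition. Compound 1 `Cc1ccc(F)cc1N(C)C(=O)c1ccc(-c2ccc(OS(N)(=O)=O)cc2)o1` gives 40 nM, and compound 2 `Cc1c(F)cccc1N(C)C(=O)c1ccc(-c2ccc(OS(N)(=O)=O)cc2)o1` gives 27 nM; the step of a 1.5-fold lower number from compound 1 to compound 2 (0.17 log units; within the scatter) lies within the scatter. Compound 3 `Cc1cccnc1N(C)C(=O)c1ccc(-c2ccc(OS(N)(=O)=O)cc2)o1` gives 1100 nM and stands as the weakest of the three: the step of a 28-fold higher number from compound 1 to compound 3 (1.44 log units; beyond the scatter) and the step of a 41-fold higher number from compound 2 to compound 3 (1.61 log units; beyond the scatter) are both large and beyond the scatter, so replacing either fluorinated methylphenyl group with 3-methylpyridin-2-yl costs a great deal of inhibition.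

Compound 4 `Cc1ncccc1N(C)C(=O)c1ccc(-c2ccc(OS(N)(=O)=O)cc2)o1` differs from compound 3 only in the arrangement of the same atoms: 2-methylpyridin-3-yl in place of 3-methylpyridin-2-yl on an amide-type nitrogen. Among the compounds with values here, no measured pair shows what moving the ring nitrogen and the methyl group within a pyridine does in this assay. The two large steps from compound 1 and compound 2 to compound 3 show only that this particular pyridine is poorly tolerated; they do not tell whether its isomer shares that fate. Compound 4 is therefore expected to land somewhere between the phenyl compounds and compound 3, with wide uncertainty, giving an estimated step of a 2.8-fold lower number from compound 3 to compound 4 (0.44 log units; beyond the scatter). The estimate for compound 4 is 400 nM, within a range from 100 nM to 2000 nM.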

Compound 4, half-maximal inhibitory concentration: 270 nM
Compound 4: the middle estimate sits 1.5-fold (0.17 log units) above what was measured; the measured number falls inside the stated range.
By their numbers in this assay, from the lowest: compounds 2 and 1 (each within the scatter of the next); then compound 4; then compound 3.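

In this assay, the result shows that this place on the amide-type nitrogen responds to how the pyridine is arranged, not only to whether a pyridine is there: exchanging 3-methylpyridin-2-yl for 2-methylpyridin-3-yl, with the same atoms joined differently, gives a 4.1-fold lower number from compound 3 to compound 4 (0.61 log units; beyond the scatter). Part of the large loss seen earlier therefore belongs to the particular isomer, yet the better pyridine still does not match either fluorinated phenyl compound, as a 6.8-fold higher number from compound 1 to compound 4 (0.83 log units; beyond the scatter) and a 10-fold higher number from compound 2 to compound 4 (1.00 log units; beyond the scatter) both show. Nothing available here explains why the two isomers differ.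

The compounds shown leave open how much the methyl group contributes in the pyridine series, which a plain pyridin-3-yl group or a 2-methoxypyridin-3-yl group would help to settle. They also leave open whether adding a fluorine to the better pyridine, as in 5-fluoro-2-methylpyridin-3-yl, would recover more of the inhibition seen with the phenyl compounds, and whether a plain 2-methylphenyl group would perform like its fluorinated relatives.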